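The compounds below may be only part of what the source reports. "The series", "measured", "known", "first", "only" and "open" are said of these compounds alone.

Measured so far in a functional assay on TK-10 cells (Homo sapiens) for inhibition, read by sulforhodamine B assay, with a stated time of 48 h; on this read-out higher numbers stand for weaker inhibition of growth and lower numbers for stronger inhibition of growth

compound 1 `O=C(Nc1cccc(-n2cc(-c3ccncc3)c(-c3ccc(Cl)c(O)c3)n2)c1)Nc1cccc(C(F)(F)F)c1` gives 2120 nM
compound 2 `COc1cc(-c2nn(-c3cccc(NC(=O)Nc4ccc(Cl)c(Cl)c4)c3)cc2-c2ccncc2)ccc1Cl` gives 1430 nM
compound 3 `O=C(Nc1cccc(-n2cc(-c3ccncc3)c(-c3ccc(Cl)c(O)c3)n2)c1)Nc1ccc(Cl)c(Cl)c1` gives 1910 nM

Compound 1 lies within the scatter of both other compounds, so the three values show no order. Compound 4 `O=C(Nc1cccc(-n2cc(-c3ccncc3)c(-c3ccc(Cl)c(O)c3)n2)c1)Nc1cc(C(F)(F)F)cc(C(F)(F)F)c1` carries one change from compound 1, trifluoromethyl in place of hydrogen on an aromatic carbon, meta to a trifluoromethyl group: trifluoromethyl in place of hydrogen on an aromatic carbon is the whole difference. The nearest evidence is a 1.1-fold lower number from compound 1 to compound 3 (0.05 log units; within the scatter) on the same end of the molecule. The step of a 1.3-fold higher number from compound 2 to compound 3 (0.13 log units; within the scatter) lies elsewhere and bears less. Among the measured compounds shown here, no measured step adds a trifluoromethyl group, so the range stays wide. In this assay no step beyond the scatter is expected, and a 1.1-fold lower number from compound 1 to compound 4 (0.03 log units; within the scatter) is the expected step here. Compound 4 is estimated at 2000 nM within an expected range of 900 nM to 4500 nM in this read-out.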

Compound 4, concentration for 50% growth inhibition: 959 nM
Compound 4: the middle estimate sits 2.1-fold (0.32 log units) above what was measured, and the stated range covers the measured number.
By their numbers in this assay, from the lowest: compounds 4, 2, 3 and 1 (each within the scatter of the next, the first and the last beyond it).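

In this assay, adding trifluoromethyl on this aromatic carbon, meta to a trifluoromethyl group, gives the first step beyond the scatter among the compounds shown (a 2.2-fold lower number from compound 1 to compound 4 (0.34 log units; beyond the scatter)), though a modest one. The earlier steps all stayed within the scatter, so this position is the first shown where a single change separates two compounds. Nothing available accounts for the step.

Open, as far as these compounds go, is whether an amine or a carboxylic acid on this same carbon would move the number in the same direction, and so whether the step is particular to trifluoromethyl.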